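This account rests on a few compounds, and the source may have more. Where it says the series, first, only, none or still open, it means among the compounds named here.

Measured so far in a functional assay on B16-F10 cells (Mus musculus) for cytotoxicity, read by MTT assay, with a stated time of 48 h; a lower number here means a stronger inhibitor, a higher number a weaker inhibitor:

Compound 1 `Cc1ccc2nc(Nc3nc4ccccc4s3)sc2c1` gives > 50000 nM, a limit of the assay.
Compound 2 `Cc1ccc2nc(NC(=S)Nc3ccccc3)sc2c1` gives > 50000 nM, also a limit.
Compound 3 `c1ccc2sc(Nc3nc4ccccc4s3)nc2c1` gives > 50000 nM, again a limit.

Within the data shown here, every value so far sits at the limit of > 50000 nM in this assay, at which 3 of the 3 values shown sit, so no number is known for any compound. Compound 1 and compound 3 differ by hydrogen in place of methyl on an aromatic carbon; the step that the two limits leave unreadable from compound 1 to compound 3 is unreadable, both ends being limits. Compound 2 keeps the methyl of compound 1, but the difference between the two cores is not broken down here.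

Compound 4 `S=C(Nc1ccccc1)Nc1nc2ccccc2s1`, not yet measured, differs from compound 2 by hydrogen in place of methyl on an aromatic carbon, the same change as from compound 1 to compound 3, at the same place. Compound 4 is expected to remain at a limit in this assay, the expected step being a step that the limit leaves unreadable from compound 2 to compound 4. This expectation rests on compound 2, which in this assay gives only > 50000 nM. It also rests on compound 3, which after the same change gives only > 50000 nM. For compound 4 the estimated value in this assay is 80000 nM, within a range from 40000 nM to 300000 nM, most likely reported as a limit only.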

Compound 4, half-maximal inhibitory concentration: > 50000 nM
Compound 4: only a limit was reported (the forecaster's own chance of this, stated with the estimate: 85%); the middle value lies beyond the limit too.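

In this assay compound 2 and compound 4 both stand only at a limit, so no step can be read between them: the limit of > 50000 nM in this assay, at which 4 of the 4 values shown sit.

The compounds shown leave open what number any of them would give, and so whether hydrogen in place of methyl on an aromatic carbon changes the read-out at all in either pair.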